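The source may report more compounds than this note shows. Statements on the series, on what has been measured and on what is new or still open speak of the compounds shown alone.

Measured compounds:
compound 1 `COc1ccc(OC)c(/C=C/c2nnc(Nc3ccc(Cl)cc3)o2)c1` — 2710 nM
compound 2 `COc1ccc(OC)c(/C=C/C(=O)N/N=C/c2ccc(Cl)cc2)c1` — 284 nM

Both compounds have been run in a functional assay on Hs-578T cells (Homo sapiens) for antiproliferative activity, read by sulforhodamine B assay, with a stated time of 48 h; on this read-out lower numbers stand for stronger inhibition of growth and higher numbers for weaker inhibition of growth. In this assay compound 1 gives 2710 nM and compound 2 gives 284 nM. Compound 2 thus has the lower of the two numbers, and its gap to compound 1 lies beyond the scatter of repeated measurements; the two structures differ in more than one place, so the gap is not assigned to a single change.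

Compound 3 `COc1ccc(OC)c(/C=C/C(=O)N/N=C/c2ccccc2)c1` is the next compound of the series and has not yet been measured. It differs from compound 2 in one place: hydrogen in place of chloro on an aromatic carbon. Among the measured compounds shown here, no single-change step of this kind is known, so the size of the step is expected on general grounds only. The expectation is a modest step toward weaker inhibition of growth, one that may well fall within the scatter. For compound 3 the expected value in this assay is 600 nM, with a range from 250 nM to 1500 nM. This estimate corresponds to an expected step of a 2.1-fold higher number from compound 2 to compound 3 (0.32 log units; beyond the scatter).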

Compound 3, concentration for 50% growth inhibition: 9070 nM
Compound 3: middle estimate off by 15-fold (1.18 log units), on the low side, and the stated range ends below it.
By their numbers in this assay, from the lowest: compound 2; then compound 1; then compound 3.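

In this assay the change from 4-chlorophenyl to phenyl gives a 32-fold higher number from compound 2 to compound 3 (1.50 log units; beyond the scatter) as a large step beyond the scatter, so in this pair the growth inhibition depends strongly on the chloro on an aromatic carbon para to a large group. Among the compounds shown here, this is the first single-change reading, since compound 1 and compound 2 differ in more than one place and their gap could not be assigned to any one part of the structure, whereas here a single heavy atom separates the two compounds. No measurement in hand bears on what lies behind this step.

The compounds shown leave open whether the effect belongs to chloro itself or would also appear with another group on the same aromatic carbon, such as fluoro, bromo, methyl or methoxy, and whether any of these would match or pass compound 2 at 284 nM in this read-out. They also leave open whether the same change from 4-chlorophenyl to phenyl would carry a step of similar size on the core of compound 1.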